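The source may hold more compounds than are shown below. What is called first, only, known or untested is meant among the compounds shown, and "the series" means these compounds.

Measured so far: compound 1 `Cc1cn(COC(CO)CO)c2ncnc(N)c12` and compound 2 `CCNc1ncnc2c1c(Cl)cn2COC(CO)CO`.

In a functional assay on L1210 cells (Mus musculus) for inhibition (on this read-out higher numbers stand for weaker inhibition and lower numbers for stronger inhibition), compound 1 gives only a limit, > 100000 nM. In this assay compound 2 likewise gives only a limit, > 100000 nM. Compound 2 therefore stands at the edge of what this assay can report, and the same holds for every value shown, because of the limit of > 100000 nM in this assay, at which 2 of the 2 values shown sit. The unmeasured compound 3 `Nc1ncnc2c1c(Cl)cn2COC(CO)CO` differs from compound 2 by hydrogen in place of ethyl on a nitrogen on an aromatic ring. No step beyond the usual scatter is expected in either direction. The expected step from compound 2 to compound 3 is a step that the limit leaves unreadable from compound 2 to compound 3. Compound 3 is estimated at 150000 nM, within 50000 nM to 500000 nM, most likely again reported only as a limit.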

Compound 3, half-maximal inhibitory concentration: 2300 nM
Beside the measured number, compound 3's estimate is 65-fold (1.81 log units) above it; the measured number lies below the stated range.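

In this assay, ethylamino to amino on the aromatic ring gives an at least 43-fold lower number from compound 2 to compound 3 (1.63 log units; beyond the scatter), so the group on this nitrogen can decide whether inhibition is measurable at all. On the aromatic carbon, chloro in place of methyl gives an at least 43-fold lower number from compound 1 to compound 3 (1.63 log units; beyond the scatter), so with amino on the nitrogen, the change from methyl to chloro matters as well. Both steps are minimum sizes, and their full sizes stay unknown: the limit of > 100000 nM in this assay, at which 2 of the 3 values shown sit.

On these data alone, it remains open how a methyl group or a longer chain on that nitrogen would behave, and whether bromo or a nitrile on the aromatic carbon could replace chloro.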